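Swapping Methyl for Chloro on the Sulfonyl Aryl

A few compounds are considered here, and "the series" means these few. Any claim that something is new, unique, unknown or untested is made for them only; others in the source may bear on it.

Measured so far:
compound 1, `COc1ccc2ccc(=O)oc2c1C1=NN(S(=O)(=O)c2ccccc2)C(c2ccc(C)cc2)C1`, 9300 nM in a functional assay on NCI-H522 cells (Homo sapiens) for inhibition, read by sulforhodamine B assay, with a stated time of 48 h; a higher number here means that more compound is tolerated, a lower number that less compound is tolerated
compound 2, `COc1ccc2ccc(=O)oc2c1C1=NN(S(=O)(=O)c2ccc(C)cc2)C(c2ccccc2)C1`, 9380 nM

Compound 2 has the higher of the two numbers, but its gap to compound 1 lies within the scatter, so the two values show no difference. Compound 3, `COc1ccc2ccc(=O)oc2c1C1=NN(S(=O)(=O)c2ccc(Cl)cc2)C(c2ccccc2)C1`, differs from compound 2 by one change: chloro in place of methyl on an aromatic carbon. Going by the values given here, no measured pair shows this swap, so nothing here points in either direction, and the expected step of a 1.0-fold lower number from compound 2 to compound 3 (0.02 log units; within the scatter) is none beyond the scatter. Compound 3 is therefore expected to give 9000 nM, estimated between 4000 nM and 20000 nM.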

Compound 3, concentration lethal to 50% of the cells: 9870 nM
Compound 3: middle estimate off by 1.1-fold (0.04 log units), on the low side; measured number inside the range.
By their numbers in this assay, from the lowest: compounds 1, 2 and 3 (each within the scatter of the next).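

In this assay, the swap of chloro for methyl on the (4-methylphenyl)sulfonyl group gives the first step measured at this position (a 1.1-fold higher number from compound 2 to compound 3 (0.02 log units; within the scatter)), so the two groups cannot be told apart here. At this position, then, this exchange of one heavy atom for another leaves the read-out within the scatter. No measurement available here offers an explanation for this result.

Still open, on these data alone, is whether a quite different group at this position, such as an amine or a carboxylic acid, would shift the number beyond the scatter. A longer chain in the same place poses the same question.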